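This account rests on a few compounds, and the source may have more. Where it says the series, first, only, none or still open, it means among the compounds named here.

In an ADME assay on MT4 cells (Homo sapiens) for cytotoxicity, read by MTT assay, with a stated time of 5 days (on this read-out lower numbers stand for higher toxicity in this test and higher numbers for lower toxicity in this test), compound 1 (`Cc1cc(C)cc(Oc2nc(NCCn3ccc(=O)[nH]c3=O)ncc2Cl)c1`) gives > 322000 nM, which is a limit of the assay and not an exact number. Compound 2 (`Cc1cc(C)c(Oc2nc(NCCn3ccc(=O)[nH]c3=O)ncc2Cl)c(C)c1`) gives 2490 nM. Putting 2,4,6-trimethylphenyl in place of 3,5-dimethylphenyl on the oxygen produced a large change, an at least 120-fold lower number from compound 1 to compound 2 (2.11 log units; beyond the scatter).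

Compound 3 (`Cc1cc(C)cc(Oc2ccnc(NCCn3ccc(=O)[nH]c3=O)n2)c1`) differs from compound 1 in another way, with hydrogen in place of chloro on an aromatic carbon. Going by the values given here, no measured step covers this swap, so the evidence is thin. Among the compounds with values here, the one large step, an at least 120-fold lower number from compound 1 to compound 2 (2.11 log units; beyond the scatter), went with the 2,4,6-trimethylphenyl group, which compound 3 does not carry. Compound 3 keeps the 3,5-dimethylphenoxy group, so no shift beyond the scatter is expected in this assay, and it may also return only a limit. The estimated change is an at least 1.2-fold lower number from compound 1 to compound 3 (0.10 log units; that floor lies within the scatter). For compound 3 the expected value is 250000 nM, with an estimated range from 70000 nM to 400000 nM.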

Compound 3, half-maximal cytotoxic concentration: 74800 nM
Beside the measured number, compound 3's estimate is 3.3-fold (0.52 log units) above it; the range from low to high includes it.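

Until now, only the group on the oxygen had been seen to move the number in this assay; the chloro place on the ring now does so too, with an at least 4.3-fold lower number from compound 1 to compound 3 (0.63 log units; beyond the scatter). Hydrogen in place of chloro, ortho to the 3,5-dimethylphenoxy group, therefore matters on its own, and keeping the 3,5-dimethylphenoxy group does not by itself keep the number unchanged. Compound 1 gives a limit and not an exact number, so this step has a floor but no known full size: the limit of > 322000 nM in this assay, at which 1 of the 3 values shown sits.

On these data alone, whether fluoro, methyl or an amine at this place would give a number closer to that of compound 3 or to the limit of compound 1 stays open. Also open, as far as these compounds go, is how hydrogen in place of chloro would act in compound 2, which carries the 2,4,6-trimethylphenyl group.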